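Fluoro added to the anilino group: small step expected

The compounds below may be only part of what the source reports. "The series", "measured", "known", "first", "only" and "open" are said of these compounds alone.

Going by the values given here, in a functional assay on PC-3 cells (Homo sapiens) for cytotoxicity, read by MTT assay, with a stated time of 72 h (on this read-out lower numbers stand for stronger inhibition and higher numbers for weaker inhibition), compound 2 `FC(F)(F)c1ccc(CSc2nc(Nc3ccccc3)c3ccccc3n2)cc1` gives 20000 nM, the higher of the two numbers known so far, and compound 1 `CCCCCCCCNc1nc(SCc2ccc(C(F)(F)F)cc2)nc2ccccc12` gives 10500 nM; the only measured step, a 1.9-fold higher number from compound 1 to compound 2 (0.28 log units; within the scatter), lies within the scatter. Compound 3 `Fc1ccc(Nc2nc(SCc3ccc(C(F)(F)F)cc3)nc3ccccc23)cc1` differs from compound 2 by fluoro in place of hydrogen on an aromatic carbon, sitting on an aromatic carbon of a six-membered aromatic ring of carbon only. Among the compounds with values here, no measured step concerns a fluoro for hydrogen exchange, and the one measured step was itself within the scatter, so nothing beyond the scatter is expected in this assay, in either direction. The step is estimated as no change at the digits printed from compound 2 to compound 3 (within the scatter). Compound 3 is expected near 20000 nM, between 8000 nM and 50000 nM.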

Compound 3, half-maximal inhibitory concentration: 7070 nM
Beside the measured number, compound 3's estimate is 2.8-fold (0.45 log units) above it; the measured number lies below the stated range.
By their numbers in this assay, from the lowest: compounds 3, 1 and 2 (each within the scatter of the next, the first and the last beyond it).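

In this assay, fluoro on the aromatic carbon para to a large group gives a 2.8-fold lower number from compound 2 to compound 3 (0.45 log units; beyond the scatter), a modest step and the first in the series beyond the scatter. Exchanging octyl for 4-fluorophenyl on the nitrogen gives a 1.5-fold lower number from compound 1 to compound 3 (0.17 log units; within the scatter), which lies within the scatter, so these two groups are not separated here. Nothing available explains the fluoro step.

Going by these compounds, it remains open whether chloro, methoxy or a carboxylic acid on the same carbon would shift the number as fluoro does. On these data alone, whether fluoro elsewhere on that ring gives the same step also remains open.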